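The source may report more compounds than this note shows. Statements on the series, on what has been measured and on what is new or still open speak of the compounds shown alone.

Two members of the series have numbers in a functional assay on HeLa cells (Homo sapiens) for cytotoxicity, read by neutral red uptake, with a stated time of 3 days (on this read-out lower numbers stand for stronger inhibition and higher numbers for weaker inhibition), so far. Compound 1 `COc1c(F)c(N)c2c(=O)cc(-c3ccc(N)c(F)c3)oc2c1F` gives 34000 nM, and compound 2 `Nc1ccc(-c2cc(=O)c3c(N)c(F)c(CO)c(F)c3o2)cc1F` gives 24000 nM. For the measured compounds named here, the only step that can be read between them is a 1.4-fold lower number from compound 1 to compound 2 (0.15 log units; within the scatter); the two numbers therefore sit within the scatter of each other, and compound 2 is simply the one with the smaller number of the two.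

Compound 3 `CCCOCc1c(F)c(N)c2c(=O)cc(-c3ccc(N)c(F)c3)oc2c1F` is the next compound. It differs from compound 2 in one place: propyl in place of hydrogen on an oxygen on a saturated carbon. Going by the values given here, the single step on record, from compound 1 to compound 2, also touched the substituent carrying this oxygen and stayed within the scatter, so nothing points to a shift beyond the scatter in this assay.

Compound 3 is expected to give roughly 24000 nM, between 10000 nM and 60000 nM, which means an expected step of no change at the digits printed from compound 2 to compound 3 (within the scatter).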

Compound 3, half-maximal inhibitory concentration: 78000 nM
Estimate against measurement, compound 3: 3.3-fold (0.51 log units) below; measured number above the stated range.
By their numbers in this assay, from the lowest: compounds 2 and 1 (each within the scatter of the next); then compound 3.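

In this assay, for the compounds shown here, propyl on the hydroxymethyl oxygen gives the first step that clears the scatter, a 3.3-fold higher number from compound 2 to compound 3 (0.51 log units; beyond the scatter), so this substituent can shift the number even though the exchange of methoxy for hydroxymethyl did not. The comparison with the methoxy compound runs the same way, a 2.3-fold higher number from compound 1 to compound 3 (0.36 log units; beyond the scatter), and places propoxymethyl on the weaker side of both smaller groups, with the step in each case modest. Nothing on hand gives a reason for this shift.

One propoxymethyl compound cannot show whether the number climbs steadily with chain length or whether any ether beyond methoxy behaves alike. An ethoxymethyl or butoxymethyl group would test the chain, and an aminomethyl or carboxylic acid group on the same aromatic carbon would test whether this position tolerates other kinds of substituent.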